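Spiro-oxindole series: triazole aryl swap, chloro to dinitro

This account rests on a few compounds, and the source may have more. Where it says the series, first, only, none or still open, it means among the compounds named here.

Measured so far in a functional assay on MCF7 cells (Homo sapiens) for antiproliferative activity, read by MTT assay, with a stated time of 48 h; a higher number here means a weaker inhibitor, a lower number a stronger inhibitor:
- compound 1 `N#CC1=C(N)Oc2c(c3nc4ccccc4nc3c3ccccc23)C12C(=O)N(Cc1cnnn1-c1ccc(N)cc1)c1ccccc12`: > 50000 nM
- compound 2 `N#CC1=C(N)Oc2c(N)cc3nc4ccccc4nc3c2C12C(=O)N(Cc1cnnn1-c1ccc(Cl)cc1)c1ccccc12`: > 50000 nM

Both values are limits of this assay, not numbers. For compound 2 the result > 50000 nM is a limit, and the limit of > 50000 nM in this assay, at which 2 of the 2 values shown sit, shows where it sits. Compound 3 `N#CC1=C(N)Oc2c(N)cc3nc4ccccc4nc3c2C12C(=O)N(Cc1cnnn1-c1ccc([N+](=O)[O-])cc1[N+](=O)[O-])c1ccccc12` differs from compound 2 by 2,4-dinitrophenyl in place of 4-chlorophenyl on an aromatic nitrogen. For the measured compounds named here, no measured step points in either direction, so the change from compound 2 to compound 3 is expected to stay within the scatter, a number no higher from compound 2 to compound 3 (the limit leaves the size open), most likely leaving only a limit again. Compound 3 is therefore estimated at 50000 nM, with a range from 15000 nM to 100000 nM.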

Compound 3, half-maximal inhibitory concentration: 20900 nM
Compound 3: the middle estimate sits 2.4-fold (0.38 log units) above what was measured; measured number inside the range.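

In this assay, 2,4-dinitrophenyl in place of 4-chlorophenyl on the aromatic nitrogen gives an at least 2.3-fold lower number from compound 2 to compound 3 (0.37 log units; beyond the scatter), so this position can bring the read-out down to a measurable number on this core. As far as these compounds go, the size of the step stays open-ended, as its starting point is a limit of the assay and not a number. Compound 1 and compound 2 both remain at such a limit: the limit of > 50000 nM in this assay, at which 2 of the 3 values shown sit.

Which of the two nitro groups carries the step remains open. Also open, from the compounds shown here alone, is how a phenyl bearing a single nitro group, a methoxy group or an amine would read at this position on the same core.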